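A few compounds are considered here, and "the series" means these few. Any claim that something is new, unique, unknown or untested is made for them only; others in the source may bear on it.

Compound 1 `C#CCSc1nc2nc(C)cc(Nc3cc(-c4ccccc4)[nH]n3)n2n1` and compound 2 `C=CCSc1nc2nc(C)cc(Nc3cc(-c4ccccc4)[nH]n3)n2n1` share one core and differ only in the group on a saturated chain carbon bound to a sulfur. In a functional assay on PC-9 cells (Homo sapiens) for inhibition, read by MTT assay, with a stated time of 72 h (a lower number here means a stronger inhibitor, a higher number a weaker inhibitor), compound 1 gives > 50000 nM, which is a limit of the assay and not a number. Compound 2 gives > 50000 nM, which is likewise a limit. Compound 2 therefore offers no number to start from, and the evidence so far is the limit of > 50000 nM in this assay, at which 2 of the 2 values shown sit.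

Compound 3 `Cc1cc(Nc2cc(-c3ccccc3)[nH]n2)n2nc(SCc3csc4ccccc34)nc2n1` keeps the core but carries 1-benzothiophen-3-yl in place of vinyl on that same carbon: 1-benzothiophen-3-yl in place of vinyl on a saturated chain carbon bound to a sulfur. Among the measured compounds shown here, the only measured step at this place, a step that the two limits leave unreadable from compound 1 to compound 2, has no readable size, so it sets no expected size for this much larger change. Any gain in this assay would be a judgement on the structural change alone, and compound 3 may also stay at the limit. A modest move toward stronger inhibition is expected, and the expected step is an at least 2.0-fold lower number from compound 2 to compound 3 (0.30 log units; that floor lies within the scatter). Compound 3 is estimated at 25000 nM, with an expected range from 5000 nM to 50000 nM.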

Compound 3, half-maximal inhibitory concentration: 4420 nM
The estimate for compound 3 lay 5.7-fold (0.75 log units) above the measured number; measured number outside the range, below it.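

At this place, on a saturated chain carbon bound to a sulfur, the group can bring a compound from the limit to a measurable number in this assay: 1-benzothiophen-3-yl in place of vinyl gives an at least 11-fold lower number from compound 2 to compound 3 (1.05 log units; beyond the scatter), and the same group in place of ethynyl gives an at least 11-fold lower number from compound 1 to compound 3 (1.05 log units; beyond the scatter). The step between the two small groups cannot be read, so the earlier pair could not show that this place responds at all; both new steps are large and lie beyond the scatter. Compound 3 is the only one of the three with a number rather than a limit of the assay: the limit of > 50000 nM in this assay, at which 2 of the 3 values shown sit.

As far as these compounds go, the change swaps a small open group for a fused one, so it remains open whether the gain needs both the five-membered and the six-membered aromatic ring, or the sulfur of the entering group. From the compounds shown here alone, a phenyl, a 3-thienyl or a 1-naphthyl group on the same carbon would separate these parts, and it is also open whether any other group at this place would give a lower number than compound 3 does.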